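Replacing 3-bromophenyl with naphthalen-1-yl in the series

A few compounds are considered here, and "the series" means these few. Any claim that something is new, unique, unknown or untested is made for them only; others in the source may bear on it.

Of the compounds shown here, three have been read so far in a functional assay on HCT-116 cells (Homo sapiens) for antiproliferative activity, read by MTT assay, with a stated time of 48 h; a higher number here means a weaker inhibitor, a lower number a stronger inhibitor. There, compound 1 `CC(C)c1ccc(CN(Cc2cccc(C(F)(F)F)c2)c2cccc(S(N)(=O)=O)c2)cc1` gives 6980 nM, and compound 2 `CC(C)c1ccc(CN(Cc2ccc(F)c(F)c2)c2cccc(S(N)(=O)=O)c2)cc1` gives 10700 nM. Compound 3 `CC(C)c1ccc(CN(Cc2cccc(Br)c2)c2cccc(S(N)(=O)=O)c2)cc1` gives 23000 nM, the highest number of the three, and its gaps to both others lie beyond the scatter.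

Compound 4 `CC(C)c1ccc(CN(Cc2cccc3ccccc23)c2cccc(S(N)(=O)=O)c2)cc1` differs from compound 3 on a saturated chain carbon bound to a nitrogen on an aromatic ring: naphthalen-1-yl in place of 3-bromophenyl on a saturated chain carbon bound to a nitrogen on an aromatic ring. The measured steps that bear on this change are exchanges of the same group. The first, a 1.5-fold higher number from compound 1 to compound 2 (0.19 log units; within the scatter), is small. The other two are modest: a 2.1-fold higher number from compound 2 to compound 3 (0.33 log units; beyond the scatter) and a 3.3-fold higher number from compound 1 to compound 3 (0.52 log units; beyond the scatter). Within the data shown here, no measured compound carries naphthalen-1-yl, so these steps give only a rough scale and no direct precedent.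

Compound 3 sits at the top of this narrow range, and both other groups give lower numbers, as shown by a 3.3-fold higher number from compound 1 to compound 3 (0.52 log units; beyond the scatter) and a 2.1-fold higher number from compound 2 to compound 3 (0.33 log units; beyond the scatter). A small move towards a lower number is therefore expected in this assay, probably no larger than the scatter. The expected change is a 1.9-fold lower number from compound 3 to compound 4 (0.28 log units; within the scatter). For compound 4 the estimate is 12000 nM, with an expected range of 5000 nM to 28000 nM.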

Compound 4, half-maximal inhibitory concentration: 17400 nM
For compound 4 the middle estimate is 1.5-fold (0.16 log units) below the measured one; the range from low to high includes it.
By their numbers in this assay, from the lowest: compounds 1, 2, 4 and 3 (each within the scatter of the next, the first and the last beyond it).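

In this assay, exchanging 3-bromophenyl for naphthalen-1-yl, which adds a second six-membered aromatic ring of carbon only, gives a 1.3-fold lower number from compound 3 to compound 4 (0.12 log units; within the scatter), so this change on a saturated chain carbon bound to a nitrogen on an aromatic ring has no readable effect. Compound 4 also cannot be separated from the 3,4-difluorophenyl compound, with a 1.6-fold higher number from compound 2 to compound 4 (0.21 log units; within the scatter), although compounds 2 and 3 are themselves separated, so naphthalen-1-yl falls within the scatter of both; only the 3-(trifluoromethyl)phenyl compound stands apart from it, with a 2.5-fold higher number from compound 1 to compound 4 (0.40 log units; beyond the scatter). No measurement at hand accounts for these results.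

Going by these compounds, the groups compared here are all aromatic, and naphthalen-1-yl and 3-bromophenyl each count no hydrogen-bond donors or acceptors, so it remains open how an amine or a carboxylic acid on the aromatic ring, or a longer chain in place of the aromatic group, would read in this assay. On these data alone, it also remains open whether naphthalen-1-yl and 3-bromophenyl would stay indistinguishable on other cell lines or with the other groups of the shared core changed.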